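A few compounds are considered here, and "the series" means these few. Any claim that something is new, unique, unknown or untested is made for them only; others in the source may bear on it.

Compound 1 `CC[C@@H]1C(=O)N(C)c2cnc(-n3ccc4cc(C(N)=O)ccc43)nc2N1C1CCCC1`: 3380 nM
Compound 2 `CCCNS(=O)(=O)c1ccc(Nc2ncc3c(n2)N(C2CCCC2)[C@H](CC)C(=O)N3C)cc1`: 2100 nM
Compound 3 `CCC1C(=O)N(C)c2cnc(-n3ccc4cc(F)ccc43)nc2N1c1ccn(C)n1`: 28600 nM

All three compounds were tested in a functional assay on NCI-H1975 cells (Homo sapiens) for antiproliferative activity, read by CCK-8 assay, with a stated time of 72 h; a higher number here means a weaker inhibitor of growth, a lower number a stronger inhibitor of growth. Compound 1 lies within the scatter of compound 2, while compound 3 gives a higher number than compound 1, beyond the scatter. Compound 4 `CCCNC(=O)c1ccc2c(ccn2-c2ncc3c(n2)N(C2CCCC2)[C@H](CC)C(=O)N3C)c1` differs from compound 1 in one place: propyl in place of hydrogen on an amide-type nitrogen. Among the measured compounds shown here, no pair of measured compounds shows this change directly. Compound 2 also carries a propyl group on a nitrogen and gives 2100 nM, so only a small move towards a lower number is expected in this assay, possibly none beyond the scatter. The expected step is a 1.7-fold lower number from compound 1 to compound 4 (0.23 log units; within the scatter). For compound 4 the estimated value is 2000 nM, with an expected range of 600 nM to 7000 nM.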

Compound 4, concentration for 50% growth inhibition: 786 nM
Beside the measured number, compound 4's estimate is 2.5-fold (0.41 log units) above it; measured number inside the range.
By their numbers in this assay, from the lowest: compound 4; then compounds 2 and 1 (each within the scatter of the next); then compound 3.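

In this assay, propyl in place of hydrogen on an amide-type nitrogen gives a 4.3-fold lower number from compound 1 to compound 4 (0.63 log units; beyond the scatter), the first step among these compounds that can be read directly. The carbamoyl group of compound 1 thus accepts a propyl chain on its nitrogen with a gain in growth inhibition, not a loss. Nothing measured here accounts for this gain. Going by these compounds, whether a shorter or longer chain on this nitrogen, or a chain ending in an amine or a carboxylic acid, would move the number further remains open. So does whether a second group on the same nitrogen would be tolerated.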